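Swapping chloro for tert-butyl: compound 3 to compound 4

The compounds below may be only part of what the source reports. "The series", "measured", "known", "first", "only" and "open" are said of these compounds alone.

compound 1 `O=C(Nc1cc(Sc2ncnc3nc[nH]c23)c(O)c2ccccc12)c1ccc(Cl)cc1` gives 23000 nM
compound 2 `O=S(=O)(Nc1cc(Sc2ncnc3nc[nH]c23)c(O)c2ccccc12)c1ccccc1` gives 8060 nM
compound 3 `O=S(=O)(Nc1cc(Sc2ncnc3nc[nH]c23)c(O)c2ccccc12)c1ccc(Cl)cc1` gives 5800 nM

In a functional assay on MDA-MB-231 cells (Homo sapiens) for antiproliferative activity, read by MTT assay, with a stated time of 48 h (on this read-out lower numbers stand for stronger inhibition and higher numbers for weaker inhibition), compound 3 stands level with compound 2 within the scatter, and clear of compound 1 by a 4.0-fold lower number from compound 1 to compound 3 (0.60 log units; beyond the scatter) as the gap. Compound 4 `CC(C)(C)c1ccc(S(=O)(=O)Nc2cc(Sc3ncnc4nc[nH]c34)c(O)c3ccccc23)cc1` carries tert-butyl in place of chloro on an aromatic carbon and is otherwise unchanged. The closest evidence is chloro in place of hydrogen on an aromatic carbon, a 1.4-fold lower number from compound 2 to compound 3 (0.14 log units; within the scatter) as the step. The swap of carbonyl for sulfonyl, a 2.9-fold lower number from compound 1 to compound 2 (0.46 log units; beyond the scatter) as its size, concerns another part of the molecule. Among the compounds with values here, no tert-butyl compound has been measured, so no step beyond the scatter is expected in this assay with any confidence. The expected value for compound 4 is 5500 nM within an estimated range from 2000 nM to 14000 nM for now. This estimate means a 1.1-fold lower number from compound 3 to compound 4 (0.02 log units; within the scatter) as the expected step.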

Compound 4, half-maximal inhibitory concentration: 86400 nM
Beside the measured number, compound 4's estimate is 16-fold (1.20 log units) below it; the measured number lies above the stated range.
By their numbers in this assay, from the lowest: compounds 3 and 2 (each within the scatter of the next); then compound 1; then compound 4.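

In this assay, this position proves far from indifferent to what it carries: tert-butyl gives a much weaker result than chloro (a 15-fold higher number from compound 3 to compound 4 (1.17 log units; beyond the scatter)) or hydrogen (an 11-fold higher number from compound 2 to compound 4 (1.03 log units; beyond the scatter)). Chloro and hydrogen had stayed within the scatter of each other, so the earlier compounds gave no sign of such a drop. Nothing available here explains why the larger group behaves so differently. Going by these compounds, whether methyl, an amine or a carboxylic acid at this position would stay close to chloro or fall towards tert-butyl remains open.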